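Carboxypyridine to methylpyridine on the ether oxygen: working notes

The source may hold more compounds than are shown below. What is called first, only, known or untested is meant among the compounds shown, and "the series" means these compounds.

For the measured compounds named here, in an ADME assay on PBMC cells (Homo sapiens) for cytotoxicity (a lower number here means that less compound is tolerated, a higher number that more compound is tolerated), compound 1 `CC(CCNC(=O)c1c(Cl)cncc1Cl)N1CCC(C(Oc2cccc(C(=O)O)n2)c2ccc(C(F)(F)F)cc2)CC1` gives 28700 nM, the only exact number available so far. Compound 2 `CCO/N=C(/c1ccc(Br)cc1)C1CCN(C(C)CCN(C)C(=O)c2c(C)cc[n+]([O-])c2C)CC1` gives > 182000 nM, which is a limit of the assay and not a number. Going by the values given here, compound 2 differs from compound 1 in more than one place, so the pair offers no measured step to work from.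

Compound 3 `Cc1cccnc1OC(c1ccc(C(F)(F)F)cc1)C1CCN(C(C)CCNC(=O)c2c(Cl)cncc2Cl)CC1` has not yet been measured. It keeps the rest of compound 1 and carries 3-methylpyridin-2-yl in place of 6-carboxypyridin-2-yl on an oxygen on a saturated carbon. The change removes the carboxyl-bearing group, and the hydrogen-bond donor counted with it.

Among the compounds with values here, with no measured step to draw on, the expectation rests on the structural change and on compound 1 at 28700 nM. A moderate move toward less compound tolerated in this assay is expected, modest in size but probably beyond the usual scatter: a 2.4-fold lower number from compound 1 to compound 3 (0.38 log units; beyond the scatter). For compound 3 the estimated value is 12000 nM, with an expected range from 4000 nM to 35000 nM.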

Compound 3, half-maximal cytotoxic concentration: 33000 nM
For compound 3 the middle estimate is 2.8-fold (0.44 log units) below the measured one, within the range that was stated.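

At the oxygen on a saturated carbon, 3-methylpyridin-2-yl in place of 6-carboxypyridin-2-yl gives, in this assay, a 1.1-fold higher number from compound 1 to compound 3 (0.06 log units; within the scatter). For the compounds shown here, this is the first measured step, and it shows that compound 1 and compound 3 cannot be told apart in this assay, although the carboxyl-bearing group and the hydrogen-bond donor counted with it are gone; at this position, for this pair, the carboxylic acid is not needed for the read-out to stay where it is. No measured property available here bears on this step, so the result stands without an explanation.

Going by these compounds alone, compound 2 gives > 182000 nM, which is a limit of the assay and not a number, and it differs from the other compounds in more than one place, so it adds no step at this position. Within the data shown here, with only one exchange in hand, it remains open how an unsubstituted pyridin-2-yl, a 6-methylpyridin-2-yl or a 6-aminopyridin-2-yl on the same oxygen would read, and so whether the methyl group in compound 3 has any part in the result.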